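The compounds below may be only part of what the source reports. "The series", "measured", "known", "first", "only" and "open" are said of these compounds alone.

Three analogues sharing one core have numbers in a functional assay on A-375 cells (Homo sapiens) for cytotoxicity, read by MTT assay; on this read-out lower numbers stand for stronger inhibition and higher numbers for weaker inhibition. Compound 1 `O=S(=O)(NCCNc1nccc(-c2c(-c3cccc(F)c3)nc3sccn23)n1)c1ccc(Br)cc1` gives 13500 nM. Compound 2 `O=S(=O)(NCCNc1nccc(-c2c(-c3cccc(F)c3)nc3sccn23)n1)c1ccc(F)cc1` gives 9450 nM in this assay. Compound 3 `O=S(=O)(NCCNc1nccc(-c2c(-c3cccc(F)c3)nc3sccn23)n1)c1cccc(F)c1` gives 14900 nM in this assay, which stands highest of the three numbers, though a 1.1-fold higher number from compound 1 to compound 3 (0.04 log units; within the scatter) and a 1.6-fold higher number from compound 2 to compound 3 (0.20 log units; within the scatter), so nothing separates the three. Compound 4 `O=C(NCCCNc1nccc(-c2c(-c3cccc(F)c3)nc3sccn23)n1)c1ccc(F)cc1` differs from compound 3 by (((4-fluorophenyl)carbonyl)amino)methyl in place of ((3-fluorophenyl)sulfonyl)amino on a saturated chain carbon, two bonds along the chain from a nitrogen on an aromatic ring. Of the measured steps, a 1.6-fold higher number from compound 2 to compound 3 (0.20 log units; within the scatter) speaks to the fluorine moving on the ring attached to the sulfonyl sulfur, and a 1.4-fold lower number from compound 1 to compound 2 (0.15 log units; within the scatter) speaks to exchanging the halogen on that ring; neither reached beyond the scatter. For the measured compounds named here, no measured step covers the exchange of sulfonyl for carbonyl or the added chain carbon, so no direction can be read for that part of the change. The expected step of a 1.2-fold lower number from compound 3 to compound 4 (0.09 log units; within the scatter) in this assay is therefore small, with the range widened for the uncovered part. Compound 4 is estimated at 12000 nM in this assay, within a range from 4000 nM to 36000 nM.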

Compound 4, half-maximal inhibitory concentration: 14900 nM
Estimate against measurement, compound 4: 1.2-fold (0.09 log units) below; the range from low to high includes it.
By their numbers in this assay, from the lowest: compounds 2, 1, 3 and 4 (each within the scatter of the next).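

In this assay, (((4-fluorophenyl)carbonyl)amino)methyl in place of ((3-fluorophenyl)sulfonyl)amino on the saturated chain carbon gives no change at the digits printed from compound 3 to compound 4 (within the scatter) and the same group gives a 1.6-fold higher number from compound 2 to compound 4 (0.20 log units; within the scatter) and also a 1.1-fold higher number from compound 1 to compound 4 (0.04 log units; within the scatter) when it replaces the other two sulfonyl groups. The earlier compounds shown here varied only the halogen on the ring attached to the sulfonyl sulfur, whereas these steps show that exchanging sulfonyl for carbonyl together with the added chain carbon also stays within the scatter of all three sulfonyl compounds. No supporting data bear on this result.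

For the compounds shown here, the single change combines the linker exchange and the added chain carbon, so their separate contributions remain unresolved. A longer chain, or a terminal amine or carboxylic acid in place of the fluorophenyl ring, would show whether this position can move the number beyond the scatter.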